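This account rests on a few compounds, and the source may have more. Where it says the series, first, only, none or still open, it means among the compounds named here.

Measured so far:
- Compound 1, `COc1ccc(-c2c(C#N)c(N)c(C#N)c(SC)c2-c2ccc(OC)cc2)cc1`: in an assay on isolated protein for inhibition of glucose-6-phosphatase catalytic subunit 1 (Homo sapiens), tested at 100 uM (on this read-out lower numbers stand for less inhibition and higher numbers for more inhibition at the one concentration tested (going by the name of the read-out)), compound 1 gives 5.5%.
- Compound 2, `CSc1c(C)c(-c2ccc(Cl)cc2)c(C#N)c(N)c1C#N`: in this assay compound 2 gives 19.3%.

Of the two numbers, compound 2 holds the higher one, and its gap to compound 1 lies beyond the usual scatter of this kind of measurement. Compound 3, `COc1ccc(-c2c(C)c(SC)c(C#N)c(N)c2C#N)cc1`, has not yet been measured. It differs from compound 2 in one place: methoxy in place of chloro on an aromatic carbon. Compound 1, which carries methoxy on both of its outer rings, sits well below compound 2, so the direction of the step is expected to be downward. A moderate fall is expected from compound 2 to compound 3 in this assay, of about a number 8.3 percentage points lower from compound 2 to compound 3 (within the scatter). Compound 3 is therefore expected to give roughly 11%, most likely between 2% and 24%.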

Compound 3, a percentage reported as inhibition, at one concentration (the size of the read-out at that concentration, not a potency): 12.3%
The estimate for compound 3 lay 1.3 percentage points below the measured number; the measured number falls inside the stated range.
By their numbers in this assay, from the lowest: compounds 1, 3 and 2 (each within the scatter of the next, the first and the last beyond it).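

In this assay, methoxy in place of chloro, on the aromatic carbon para to a large group, comes with a number 7 percentage points lower from compound 2 to compound 3 (within the scatter) and so gives no change at this position that can be told apart from repeat scatter. Compound 3 also gives a second one-place comparison, methyl in place of 4-methoxyphenyl on an aromatic carbon, and this comes with a number 6.8 percentage points higher from compound 1 to compound 3 (within the scatter) as its result. Neither single change can therefore be said to alter inhibition at the one concentration tested.

The compounds shown leave open whether a different group on that aromatic carbon, such as an amine or a carboxylic acid, would shift the number beyond the scatter. No other data here bear on either step or offer an explanation for it.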